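Swapping the ether-bearing amine side chain for pentan-3-yl

A few compounds are considered here, and "the series" means these few. Any claim that something is new, unique, unknown or untested is made for them only; others in the source may bear on it.

Three compounds sharing one core have been characterised in an in vitro assay on 293-EBNA cells for binding affinity to corticotropin-releasing factor receptor 1 (Homo sapiens); a higher number here means a weaker inhibitor, a lower number a stronger inhibitor. Compound 1 `CCC(COC)N(C)c1nc(C)nc2c1nnn2-c1ccc(C(C)C)cc1Br` gives 11.2 nM in this assay. Compound 2 `CCCCN(CC)c1nc(C)nc2c1nnn2-c1c(C)cc(C)nc1C` gives 65 nM. Compound 3 `COCCNc1nc(C)nc2c1nnn2-c1c(C)cc(C)cc1C` gives 1200 nM, the highest number of the three; its gap to compound 2 and its gap to compound 1 both lie beyond the scatter of repeated measurements, so compound 3 is the weakest inhibitor among the measured set.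

Compound 4 `CCC(CC)Nc1nc(C)nc2c1nnn2-c1c(C)cc(C)cc1C` has not yet been measured in this assay. It differs from compound 3 in one place: pentan-3-yl in place of 2-methoxyethyl on a nitrogen on an aromatic ring. For the measured compounds named here, no pair of measured compounds differs in exactly this way, so no measured step can be copied over.

What the measured set does show is that the compounds carrying a group without a hydrogen-bond acceptor in the side chain on that nitrogen, compound 1 and compound 2, sit at markedly lower numbers than compound 3. On that basis compound 4 is expected to give a lower number than compound 3, with a step of a 20-fold lower number from compound 3 to compound 4 (1.30 log units; beyond the scatter) that goes beyond the scatter. The estimate for compound 4 in this assay is 60 nM, within a range from 12 nM to 300 nM.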

Compound 4, inhibition constant: 5.7 nM
Beside the measured number, compound 4's estimate is 11-fold (1.02 log units) above it; the whole stated range lies above it.
By their numbers in this assay, from the lowest: compounds 4 and 1 (each within the scatter of the next); then compound 2; then compound 3.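

Replacing 2-methoxyethyl with pentan-3-yl on a nitrogen on an aromatic ring gives a 210-fold lower number from compound 3 to compound 4 (2.32 log units; beyond the scatter) in this assay, a large step that lies beyond the scatter. Compounds 1, 2 and 3 differ from one another in more than one place, so their gaps could not be assigned to this side chain, whereas here the rest of the structure stays fixed and the change at this position alone accounts for the whole step. Nothing among the data explains why the step is this large.

The step cannot say whether the lower number follows from the loss of the ether oxygen, from the branching of the chain or from the added carbon, since all three change together, and an unbranched n-pentyl chain or a branched chain that keeps its methoxy group would be needed to pull these apart. On these data alone, it also remains open whether the same replacement carries the same weight with another aryl group on the shared core, such as the bromo-substituted ring of compound 1, or on a nitrogen that bears a second alkyl group, such as the methyl group of compound 1.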